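A Methoxy Added to the Fused Ring of Compound 1

The compounds below may be only part of what the source reports. "The series", "measured", "known", "first", "only" and "open" are said of these compounds alone.

Among the two compounds measured in a functional assay on NCI/ADR-RES cells (Homo sapiens) for inhibition, read by sulforhodamine B assay, with a stated time of 48 h (on this read-out lower numbers stand for stronger inhibition of growth and higher numbers for weaker inhibition of growth), compound 1 `COc1ccc(-c2[nH]c3ccccc3c2/C=C(\C#N)S(=O)(=O)c2ccccc2)cc1` stands lowest, giving 428 nM. Compound 2 `COc1ccc2[nH]c(-c3ccccc3)c(C=C(C#N)C#N)c2c1` gives 2800 nM in this assay, and the gap between the two values lies beyond the usual scatter. Among the compounds with values here, the two compounds differ in more than one place, so their values alone do not show what any single change contributes, and no step between compounds differing in one place is available.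

Compound 3 `COc1ccc(-c2[nH]c3ccc(OC)cc3c2/C=C(\C#N)S(=O)(=O)c2ccccc2)cc1` differs from compound 1 by methoxy in place of hydrogen on an aromatic carbon. Compound 2 also carries a methoxy on its fused ring, but its other differences from compound 1 prevent any reading of that change on its own. Within the data shown here, with no single-place step to lean on, the expectation for compound 3 rests on compound 1 alone: a step of a 1.4-fold higher number from compound 1 to compound 3 (0.15 log units; within the scatter) that is estimated to be small, in either direction, and probably not beyond the scatter. Compound 3 is therefore expected to give about 600 nM in this assay, with a range from 200 nM to 2000 nM.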

Compound 3, concentration for 50% growth inhibition: 494 nM
For compound 3 the middle estimate is 1.2-fold (0.08 log units) above the measured one; the range from low to high includes it.
By their numbers in this assay, from the lowest: compounds 1 and 3 (each within the scatter of the next); then compound 2.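

Within the data shown here, the step of a 1.2-fold higher number from compound 1 to compound 3 (0.06 log units; within the scatter) is the first reading of a single change in this assay, and it concerns a place that no earlier pair could isolate: an aromatic carbon of the six-membered ring of carbon only, part of the fused system. At this position, methoxy in place of hydrogen adds 2 heavy atoms and 1 hydrogen-bond acceptor, yet the numbers for compound 1 and compound 3 cannot be told apart, so in this read-out the position accepts methoxy without a detectable penalty or gain. Nothing measured here speaks to why the step is so small.

Going by these compounds, whether this holds for other groups at the same aromatic carbon remains open: a fluorine, an amine, a carboxylic acid or a longer chain such as butoxy could give a number that stays within the scatter of compound 1 or moves well beyond it. On these data alone, it is also open whether methoxy at this position gives a similarly small step on a compound with the two nitrile groups of compound 2 in place of the phenylsulfonyl and nitrile pair.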